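Swapping a methylphenyl for a naphthyl on the arylidene arm

A few compounds are considered here, and "the series" means these few. Any claim that something is new, unique, unknown or untested is made for them only; others in the source may bear on it.

Three compounds sharing a core built around a thiazole and a thiazolidinone have been tested in a functional assay on MDA-MB-231 cells (Homo sapiens) for cytotoxicity, read by MTT assay, with a stated time of 72 h; on this read-out lower numbers stand for stronger inhibition and higher numbers for weaker inhibition. Compound 1 `O=C1N/C(=N/c2csc(-c3ccc(Cl)cc3)c2)S/C1=C\c1ccccc1` gives 18000 nM. Compound 2 `O=C1CS/C(=N\c2nc(-c3ccc(Cl)cc3)cs2)N1` reaches only the limit of the assay, > 50000 nM, and no number is known for it (the limit of > 50000 nM in this assay, at which 1 of the 3 values shown sits). Compound 3 `Cc1ccc(/C=C2\S/C(=N\c3nc(-c4ccc(Cl)cc4)cs3)NC2=O)cc1` gives 800 nM, the lower of the two numbers measured, and the gap between compound 3 and compound 1 is well beyond the usual scatter of repeated measurements.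

Compound 4 `O=C1N/C(=N/c2nc(-c3ccc(Cl)cc3)cs2)S/C1=C\c1ccc2ccccc2c1` is not yet measured. It differs from compound 3 in one place: naphthalen-2-yl in place of 4-methylphenyl on a double-bonded chain carbon bound to a double-bonded ring carbon. For the measured compounds named here, nothing among the measured compounds shows what a change of this kind does in this assay, so no direction can be read from them. Compound 4 is therefore expected to stay close to compound 3, with the step of a 1.5-fold higher number from compound 3 to compound 4 (0.18 log units; within the scatter) estimated to be within or only modestly beyond the scatter in either direction. For compound 4 the estimate is 1200 nM, with a range from 250 nM to 6000 nM.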

Compound 4, half-maximal inhibitory concentration: 900 nM
Compound 4: middle estimate off by 1.3-fold (0.12 log units), on the high side; low and high end bracket the measured number.
By their numbers in this assay, from the lowest: compounds 3 and 4 (each within the scatter of the next); then compound 1. At a limit, above all of these: compound 2.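

In this assay, replacing 4-methylphenyl with naphthalen-2-yl on a double-bonded chain carbon bound to a double-bonded ring carbon gives a 1.1-fold higher number from compound 3 to compound 4 (0.05 log units; within the scatter). For the compounds shown here, this is the first direct comparison at this position, and it shows that a two-ring aromatic group with 10 heavy atoms can stand in place of a one-ring group with 7 without a change that can be told apart from the scatter. None of the available measurements explains why the number holds across this swap.

On these data alone, it remains open whether this position needs an aromatic group at all, or whether a butyl chain could take its place. The effect of an aryl ring carrying an amine or a carboxylic acid at this position is also unknown.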